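Lengthening the shortest hydroxycarbamoyl chain

The compounds below may be only part of what the source reports. "The series", "measured", "known", "first", "only" and "open" are said of these compounds alone.

Values measured in a functional assay on MDA-MB-231 cells (Homo sapiens) for inhibition, read by MTT assay, with a stated time of 72 h (a higher number here means a weaker inhibitor, a lower number a stronger inhibitor), are as follows.
- compound 1 `Nc1ncnc2c1c(-c1cnc3[nH]ccc3c1)nn2CCCCCCCCC(=O)NO` gives 11000 nM
- compound 2 `Nc1ncnc2c1c(-c1cnc3[nH]ccc3c1)nn2CCCCC(=O)NO` gives the limit > 50000 nM
- compound 3 `Nc1ncnc2c1c(-c1cnc3[nH]ccc3c1)nn2CCC(=O)NO` gives the limit > 150000 nM

Compound 3 has no number, only the limit > 150000 nM. In compound 4 `Nc1ncnc2c1c(-c1cnc3[nH]ccc3c1)nn2CCCC(=O)NO`, (hydroxycarbamoyl)methyl stands in place of hydroxycarbamoyl on a saturated chain carbon, two bonds along the chain from an aromatic nitrogen ((hydroxycarbamoyl)methyl in place of hydroxycarbamoyl on a saturated chain carbon, two bonds along the chain from an aromatic nitrogen). Three measured steps change the same chain. The first, an at least 4.5-fold higher number from compound 1 to compound 2 (0.65 log units; beyond the scatter), is at least modest, and the second, an at least 13-fold higher number from compound 1 to compound 3 (1.13 log units; beyond the scatter), is large. The third, a step that the two limits leave unreadable from compound 2 to compound 3, gives no size. Only compound 1 reaches a number, and the chain of compound 4 is longer than that of compound 3 but shorter than that of compound 2. Compound 4 is therefore expected to stay far weaker than compound 1, and another limit is likely. The expected step, an at least 1.5-fold lower number from compound 3 to compound 4 (0.17 log units; that floor lies within the scatter), would be small, towards a lower number if it can be read at all. In this assay compound 4 is estimated at 100000 nM, with an expected range of 40000 nM to 300000 nM.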

Compound 4, half-maximal inhibitory concentration: > 150000 nM
Compound 4: a limit, no number; the forecaster's own chance of this, stated with the estimate: 75%; middle value at least 1.5-fold (0.17 log units) from the limit.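

Setting (hydroxycarbamoyl)methyl in place of hydroxycarbamoyl at this position, on a saturated chain carbon, two bonds along the chain from an aromatic nitrogen, does not bring a number into reach: in this assay compound 4 gives only a limit, > 150000 nM. Among the compounds shown here, compound 3 stops at this same limit, so the change leaves the result where it was: the limit of > 150000 nM in this assay, at which 2 of the 4 values shown sit. The one step that can be read is an at least 13-fold higher number from compound 1 to compound 4 (1.13 log units; beyond the scatter), which sets compound 4 apart from the only compound with a number, while the steps among compound 2, compound 3 and compound 4 cannot be read.

Going by these compounds, whether these three shorter chains differ from one another at all remains open. Also open, on these data alone, is how a longer chain than that of compound 1, or a carboxylic acid in place of the hydroxycarbamoyl end, would fare in this assay.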